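A few compounds are considered here, and "the series" means these few. Any claim that something is new, unique, unknown or untested is made for them only; others in the source may bear on it.

Three compounds share a core carrying an oxyacetic acid chain and a 4-methylphenyl group, and they differ on the aromatic ring of the carbonyl side. In a functional assay on a cell-free system (Platelet, plasma, Homo sapiens) for inhibition (on this read-out higher numbers stand for weaker inhibition and lower numbers for stronger inhibition), compound 1 `COc1ccc(C(=O)N(CCN2CCC(OCC(=O)O)CC2)c2ccc(C)cc2)cc1` gives 1200 nM and compound 3 `Cc1ccc(N(CCN2CCC(OCC(=O)O)CC2)C(=O)c2cccc(C(F)(F)F)c2)cc1` gives 20000 nM. Compound 2 `Cc1ccc(N(CCN2CCC(OCC(=O)O)CC2)C(=O)c2ccc(C(F)(F)F)cc2)cc1` reads > 10000 nM, which is a limit of the assay and not a number.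

Compound 4 `O=C(O)COC1CCN(CCN(C(=O)c2ccc(C(F)(F)F)cc2)c2ccc(Cl)cc2)CC1` keeps the carbonyl side of compound 2 and changes only the other aromatic ring: chloro in place of methyl on an aromatic carbon. This places chloro in place of methyl on an aromatic carbon, turning 4-methylphenyl into 4-chlorophenyl.

Among the measured compounds shown here, no measured step touches this position. The nearest evidence lies on the carbonyl side, where the change is an at least 8.3-fold higher number from compound 1 to compound 2 (0.92 log units; beyond the scatter) and a 17-fold higher number from compound 1 to compound 3 (1.22 log units; beyond the scatter), both beyond the scatter. The remaining comparison, a step that the limit leaves unreadable from compound 2 to compound 3, adds nothing. Those steps therefore cannot be carried over to the new change, and they give no direction for it.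

With no measured support for a shift, the estimated step, a step that the limit leaves unreadable from compound 2 to compound 4, is expected to stay within the scatter. The expectation starts from compound 2 at > 10000 nM, a limit, so a limit reading is also possible for the new compound. For compound 4 the expected value is 15000 nM, with an estimated range from 5000 nM to 50000 nM.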

Compound 4, half-maximal inhibitory concentration: > 10000 nM
Compound 4: only a limit was reported (the forecaster's own chance of this, stated with the estimate: 50%); the middle value does not contradict the limit.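

In this assay compound 4 gives > 10000 nM, which is a limit and not a number. Compound 2 also stands at a limit, so no step between compound 2 and compound 4 can be read: the limit of > 10000 nM in this assay, at which 2 of the 4 values shown sit.

The compounds shown leave open whether chloro in place of methyl on an aromatic carbon changes inhibition at all.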